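Replacing a methoxypiperidine urea with a bicyclic carbon amide

This account rests on a few compounds, and the source may have more. Where it says the series, first, only, none or still open, it means among the compounds named here.

Compound 1 `O=C(N1CCC(F)CC1)N1CC(c2nc(-c3cccc(Cl)c3)no2)C1` carries a carbonyl on the ring nitrogen of the shared core; in an assay on HEK293 cells for positive allosteric modulation of metabotropic glutamate receptor 5 (Homo sapiens), read by FLIPR (on this read-out lower numbers stand for an effect already at smaller amounts and higher numbers for an effect only at larger amounts of compound), compound 1 gives 990 nM. Compound 2 `O=C(c1ccccc1F)N1CC(c2nc(-c3cccc(Cl)c3)no2)C1` sits at the limit > 10000 nM in this assay. Compound 3 `COC1CCCN(C(=O)N2CC(c3nc(-c4cccc(Cl)c4)no3)C2)C1` likewise stops at the limit > 10000 nM, a value that is only a boundary, shared with one other compound (the limit of > 10000 nM in this assay, at which 2 of the 3 values shown sit). The steps of an at least 10-fold higher number from compound 1 to compound 2 (1.00 log units; beyond the scatter) and an at least 10-fold higher number from compound 1 to compound 3 (1.00 log units; beyond the scatter) are the only readable ones; the step that the two limits leave unreadable from compound 2 to compound 3 cannot be sized. Compound 4 `O=C([C@H]1CC2CCC1C2)N1CC(c2nc(-c3cccc(Cl)c3)no2)C1` differs from compound 3 by a group of 7 heavy atoms (7 carbon; 2 five-membered non-aromatic rings of carbon only) in place of a group of 8 heavy atoms (6 carbon, 1 nitrogen, 1 oxygen; one six-membered non-aromatic ring with 1 hetero atom), on a carbonyl carbon. Since compound 3 stands at a boundary, the step to compound 4 can only be level or downward. Compound 4 is estimated at 3000 nM (range 700 nM to 12000 nM), meaning an expected step of an at least 3.3-fold lower number from compound 3 to compound 4 (0.52 log units; beyond the scatter), with a fair chance that compound 4 also ends at the limit.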

Compound 4, half-maximal effective concentration: 74 nM
Compound 4: the middle estimate sits 41-fold (1.61 log units) above what was measured; measured number outside the range, below it.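

The earlier compounds shown here showed only losses at this carbonyl carbon, whereas the carbon-only group of compound 4, with its two five-membered rings, brings a 13-fold lower number from compound 1 to compound 4 (1.13 log units; beyond the scatter), so a change here can also gain. Against the other two compounds it brings an at least 130-fold lower number from compound 3 to compound 4 (2.13 log units; beyond the scatter) and an at least 130-fold lower number from compound 2 to compound 4 (2.13 log units; beyond the scatter), and both are only bounds: the limit of > 10000 nM in this assay, at which 2 of the 4 values shown sit.

The compounds shown leave open whether a plain cyclohexyl group on the carbonyl carbon would do the same. They also leave open what the opposite configuration at the defined stereocentre gives.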